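Closing the acid-bearing carbon of compound 3 into a ring

The compounds below may be only part of what the source reports. "The series", "measured", "known", "first", "only" and "open" are said of these compounds alone.

Compound 1, `O=C(O)CCC(=O)Nc1cccc(OCc2ccc3ccc(F)cc3n2)c1`, in a functional assay on ileum (Cavia porcellus) for antagonist activity at cysteinyl leukotriene receptor (Homo sapiens) (on this read-out lower numbers stand for stronger inhibition and higher numbers for weaker inhibition), compound 1 gives 200 nM.
Compound 2, `CCC(C)(CC(=O)Nc1cccc(OCc2ccc3ccc(F)cc3n2)c1)C(=O)O`, in this assay compound 2 gives 6.4 nM.
Compound 3, `CCCC(CCC)(CC(=O)Nc1cccc(OCc2ccc3ccc(F)cc3n2)c1)C(=O)O`, in this assay compound 3 gives 2 nM.

Of the three measured compounds, compound 3 stands lowest in this assay; its nearest neighbour is compound 2 and the furthest is compound 1, both separated from it by steps beyond the scatter. Compound 4, `O=C(CC1(C(=O)O)CCCCC1)Nc1cccc(OCc2ccc3ccc(F)cc3n2)c1`, carries the change (1-carboxycyclohexyl in place of 1-carboxy-1-propylbutyl on a saturated chain carbon bound to a carbonyl carbon). The two propyl arms of compound 3 are thus tied into a six-membered ring, and the group entering is one carbon smaller than the group leaving. The measured steps that bear on this all concern substitution on the same chain carbon: a 31-fold lower number from compound 1 to compound 2 (1.49 log units; beyond the scatter), a 100-fold lower number from compound 1 to compound 3 (2.00 log units; beyond the scatter) and a 3.2-fold lower number from compound 2 to compound 3 (0.51 log units; beyond the scatter). Each added carbon on that carbon lowered the number, the last addition only modestly. Compound 4 sits between compound 2 and compound 3 in carbon count, so a small rise from compound 3 is expected, a 2.0-fold higher number from compound 3 to compound 4 (0.30 log units; within the scatter), within or barely beyond the scatter. The estimate for compound 4 in this assay is 4 nM, expected to fall between 1.5 nM and 12 nM.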

Compound 4, half-maximal inhibitory concentration: 7.3 nM
Compound 4: the middle estimate sits 1.8-fold (0.26 log units) below what was measured, within the range that was stated.
By their numbers in this assay, from the lowest: compound 3; then compounds 2 and 4 (each within the scatter of the next); then compound 1.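

In this assay, going by these compounds alone, closing the two propyl arms into the 1-carboxycyclohexyl group brings a 3.7-fold higher number from compound 3 to compound 4 (0.56 log units; beyond the scatter) and is the first rise seen on this saturated chain carbon bound to a carbonyl carbon, where the earlier replacements had only lowered the number. The ring gives up the edge of the open dipropyl group yet keeps the large gain over carboxymethyl, with a 27-fold lower number from compound 1 to compound 4 (1.44 log units; beyond the scatter) on one side and a 1.1-fold higher number from compound 2 to compound 4 (0.06 log units; within the scatter) on the other, the latter leaving compound 4 level with the smaller open group. Nothing among the data explains why the ring fares worse than the open chains it replaces. As far as these compounds go, whether 1-carboxycyclopentyl or 1-carboxycyclopropyl would behave like 1-carboxycyclohexyl remains open. So does the effect of an ether oxygen inside the six-membered ring, or of a tetrazole in place of the carboxylic acid.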